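A few compounds are considered here, and "the series" means these few. Any claim that something is new, unique, unknown or untested is made for them only; others in the source may bear on it.

In a functional assay on DU-145 cells (Homo sapiens) for inhibition, read by trypan blue exclusion, with a stated time of 96 h (on this read-out lower numbers stand for stronger inhibition of growth and higher numbers for weaker inhibition of growth), compound 1 `Cc1ccc(S/C(=C/c2sccc2C)C(=O)c2ccc(Br)cc2)cc1` gives 50000 nM. Compound 3 `Cc1ccc(S/C(=C/c2sccc2C)C(=O)c2ccc(Cl)cc2)cc1` stands level with it at 50000 nM, and together they hold the highest of the three numbers, while compound 2 `Cc1ccc(C)c(/C=C(\C(=O)c2ccc(Br)cc2)S(=O)(=O)Cc2ccc(F)cc2)c1` gives a much lower 1000 nM. Compound 4 `Cc1ccc(S/C(=C/c2ccc(C)s2)C(=O)c2ccc(Br)cc2)cc1`, not yet measured, has the same atoms as compound 1, joined differently: 5-methylthiophen-2-yl in place of 3-methylthiophen-2-yl on a double-bonded chain carbon bound to a double-bonded chain carbon. It carries 5-methylthiophen-2-yl in place of 3-methylthiophen-2-yl on a double-bonded chain carbon bound to a double-bonded chain carbon. Going by the values given here, the only measured single-place step is no change at the digits printed from compound 1 to compound 3 (within the scatter), with chloro in place of bromo on an aromatic carbon. Among the compounds with values here, it bears only indirectly, since no measured step changes the thiophene group. The expected step in this assay is a 1.3-fold lower number from compound 1 to compound 4 (0.10 log units; within the scatter), with none expected beyond the scatter. Compound 4 is estimated at 40000 nM, with an expected range of 10000 nM to 100000 nM.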

Compound 4, concentration for 50% growth inhibition: > 100000 nM
Compound 4 gave a limit, no number (the forecaster's own chance of this, stated with the estimate: 20%); middle value at least 2.5-fold (0.39 log units) away from the limit.
By their numbers in this assay, from the lowest: compound 2; then compounds 1 and 3 (each within the scatter of the next). At a limit, above all of these: compound 4.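

Compound 4 reads only as a limit of the assay: the limit of > 100000 nM in this assay, at which 1 of the 4 values shown sits. In this assay, 5-methylthiophen-2-yl in place of 3-methylthiophen-2-yl gives an at least 2.0-fold higher number from compound 1 to compound 4 (0.30 log units; that floor lies within the scatter), the first step shown at this chain carbon, where the earlier compounds showed only a change of halogen. As far as these compounds go, this isomeric change therefore brought no lower number, though the true size of the step stays unknown behind the limit.

The compounds shown leave open how an unsubstituted thiophen-2-yl or a phenyl group would read at this place. They also leave open whether a dimethylamino group on the thiophene would give a lower number.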